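Swapping fluoro for nitro on a growth-inactive acid

This account rests on a few compounds, and the source may have more. Where it says the series, first, only, none or still open, it means among the compounds named here.

Measured in a functional assay on PC-3 cells (Homo sapiens) for inhibition, read by sulforhodamine B assay, with a stated time of 48 h; on this read-out higher numbers stand for weaker inhibition of growth and lower numbers for stronger inhibition of growth:
Compound 1 `CCOC(=O)c1nn(-c2ccccc2)c(-c2ccc(F)cc2)c1CNC(C)(C)C`: 69300 nM; 82100 nM (2 entries).
Compound 2 `CC(C)(C)NCc1c(C(=O)O)nn(-c2ccccc2)c1-c1ccc(F)cc1`: > 680000 nM, a limit and not a number.

Compound 1 has a real measured value, with two entries that agree within the usual scatter (the several entries of compound 1 in this assay, 69300 nM; 82100 nM (2 entries)). Compound 2 has no such value, because its only entry is a limit (the limit of > 680000 nM in this assay, at which 1 of the 2 values shown sits). Compound 3 `CC(C)(C)NCc1c(C(=O)O)nn(-c2ccccc2)c1-c1ccc([N+](=O)[O-])cc1` is compound 2 with a single change: nitro in place of fluoro on an aromatic carbon, para to a large group (nitro in place of fluoro on an aromatic carbon). The same difference can be read as 4-fluorophenyl to 4-nitrophenyl. Within the data shown here, no measured pair of compounds shows what this swap does, so the expectation rests on compound 2 alone. The expected change in this assay is an at least 1.0-fold lower number from compound 2 to compound 3 (0.02 log units; that floor lies within the scatter), which means no step beyond the scatter in either direction. Compound 3 is estimated at 640000 nM, with an expected range of 250000 nM to 1000000 nM.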

Compound 3, concentration for 50% growth inhibition: > 634000 nM
Compound 3 gave a limit, no number; the forecaster's own chance of this, stated with the estimate: 65%; the middle value lies beyond the limit too.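

Among these compounds, compound 2 and compound 3 each give only a limit and not a number in this assay, and no step between them can be read. The compounds shown leave open whether nitro in place of fluoro changes growth inhibition at all, and in which direction.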